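The source may hold more compounds than are shown below. What is called first, only, known or untested is meant among the compounds shown, and "the series" means these compounds.

Of the compounds shown here, three of the shared core have been measured in an assay on membranes from brain for displacement of a labelled ligand from Neuronal acetylcholine receptor; alpha4/beta2 (Rattus norvegicus); a higher number here means a weaker inhibitor, a lower number a stronger inhibitor. Compound 1 `CN1CCC[C@H]1COc1cccnc1I` gives 606 nM, compound 2 `Cc1ccncc1OC[C@@H]1CCCN1C` gives 4.12 nM, and compound 3 `Cc1cncc(OC[C@@H]2CCCN2C)c1` gives 0.48 nM, the lowest of the three and hence the strongest binder among them, with both other numbers beyond the scatter.

Compound 4 `CN1CCC[C@H]1COc1cncc(N)c1` differs from compound 3 in one place: amino in place of methyl on an aromatic carbon. For the measured compounds named here, no measured pair shows this kind of exchange, so the direction rests on the step alone. The expected step from compound 3 to compound 4 in this assay is a rise in the inhibition constant, a 6.3-fold higher number from compound 3 to compound 4 (0.80 log units; beyond the scatter), probably beyond the scatter but not large. Compound 4 is therefore estimated at 3 nM, within a range of 0.5 nM to 20 nM.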

Compound 4, inhibition constant: 0.63 nM
Beside the measured number, compound 4's estimate is 4.8-fold (0.68 log units) above it, and the stated range covers the measured number.
By their numbers in this assay, from the lowest: compounds 3 and 4 (each within the scatter of the next); then compound 2; then compound 1.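

In this assay, exchanging methyl for amino at this aromatic carbon, two atoms from the ring nitrogen, gives a step of a 1.3-fold higher number from compound 3 to compound 4 (0.12 log units; within the scatter) and so leaves no measurable difference. At this position, a group with a hydrogen-bond donor and a hydrogen-bond acceptor therefore serves as well as one with neither. Nothing measured here explains this result.

From the compounds shown here alone, whether a hydroxyl, a carboxylic acid or a longer chain at this carbon would also give so low a number remains open. So does whether amino would be tolerated equally at other positions on the ring.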